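The compounds below may be only part of what the source reports. "The series", "measured", "known", "first", "only" and "open" are said of these compounds alone.

The measured compounds in a functional assay on L1210 cells (Mus musculus) for antiproliferative activity (on this read-out higher numbers stand for higher potency (the scale is a negative logarithm) and lower numbers for lower potency), are:

Compound 1, `Cc1cccc(/N=N/N(C)C)c1`, gives 3.4.
Compound 2, `CN(C)/N=N/c1n[nH]cc1C(N)=O`, gives 3.49.
Compound 3, `COC(=O)c1c[nH]nc1/N=N/N(C)C`, gives 3.49.

Compound 2 stands level with compound 3 at the digits shown, the two together at the top of the three numbers, and compound 1 lies within the scatter of both, so none of the three can be set above another. Going by the values given here, the one step between neighbouring compounds, no change at the digits printed from compound 2 to compound 3 (within the scatter), concerns the carbonyl carbon only.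

Compound 4, `C=CCN(C)/N=N/c1n[nH]cc1C(N)=O`, is the next compound to be tested in this assay. Compared with compound 2, the change is:

vinyl in place of hydrogen on a saturated chain carbon bound to an amine nitrogen

Read one bond further out it is methyl to allyl, dimethylamino to allyl(methyl)amino. Among the compounds with values here, no measured step touches the amine nitrogen or the carbon bound to it, so nothing among the three compounds shows how the read-out responds to this kind of change. Within the data shown here, the only step in hand, from compound 2 to compound 3, left the number unchanged, and the three values as a whole sit close together. On that basis compound 4 is expected to stay near compound 2, with a step of a number 0.01 log units higher from compound 2 to compound 4 (within the scatter) that is not expected to exceed the scatter. The estimate for compound 4 in this assay is 3.5, within a range from 3.1 to 3.9.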

Compound 4, logarithm of the reciprocal of the active concentration, log(1/C): 3.77
Estimate against measurement, compound 4: 0.27 log units below, within the range that was stated.
By their numbers in this assay, from the lowest: compounds 1, 2, 3 and 4 (each within the scatter of the next, the first and the last beyond it).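

Going by these compounds alone, the change from dimethylamino to allyl(methyl)amino gives the first reading at a saturated chain carbon bound to an amine nitrogen, and this assay shows a number 0.28 log units higher from compound 2 to compound 4 (within the scatter). This place therefore accepts vinyl in place of hydrogen, with its 2 heavy atoms and its double bond, while the number stays within the scatter, so a single step here shows neither a gain nor a loss that can be told apart from repeated measurement. No measurement is at hand that could explain the size of this step.

From the compounds shown here alone, it remains open whether the double bond matters at all, which a propyl group on the same amine nitrogen would test against the allyl group of compound 4, and whether a longer chain such as butyl, or a benzyl group, would carry the number beyond the scatter. Going by these compounds, it is also open whether allyl(methyl)amino would read the same alongside the methyl ester of compound 3 as it does alongside the primary amide of compound 4.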